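Benzyl in place of phenyl on the ring amine nitrogen

The compounds below may be only part of what the source reports. "The series", "measured", "known", "first", "only" and "open" are said of these compounds alone.

Measured so far:
compound 1, `CCCn1c(=O)[nH]c2nc(-c3ccc(S(=O)(=O)N4CCN(c5cccc(Br)c5)CC4)cc3)[nH]c2c1=O`, > 1000 nM
compound 2, `CCCn1c(=O)[nH]c2nc(-c3ccc(S(=O)(=O)N4CCN(c5cccc(F)c5)CC4)cc3)[nH]c2c1=O`, > 1000 nM
compound 3, `CCCn1c(=O)[nH]c2nc(-c3ccc(S(=O)(=O)N4CCN(Cc5cccc(Br)c5)CC4)cc3)[nH]c2c1=O`, 928 nM

The three measured compounds share one core and differ only in the group on the amine nitrogen in a ring. In an assay on CHO cells for displacement of a labelled ligand from adenosine receptor A1 (Homo sapiens), read by scintillation counting, with a stated time of 90 min, in the presence of a further agent that is not named here (a higher number here means a weaker inhibitor, a lower number a stronger inhibitor), compound 1 gives > 1000 nM, which is a limit of the assay and not a number. Compound 2 likewise gives only a limit, > 1000 nM. Among the compounds with values here, compound 3 is the one compound with a number, 928 nM, just inside the measurable window. The steps of an at least 1.0-fold lower number from compound 1 to compound 3 (0.03 log units; that floor lies within the scatter) and an at least 1.0-fold lower number from compound 2 to compound 3 (0.03 log units; that floor lies within the scatter) can be read as floors only, because of the limit of > 1000 nM in this assay, at which 2 of the 3 values shown sit; neither floor reaches beyond the scatter. Compound 1 therefore stands at the weak end of what is shown, at the limit.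

Compound 4, `CCCn1c(=O)[nH]c2nc(-c3ccc(S(=O)(=O)N4CCN(Cc5ccc(Br)c(F)c5)CC4)cc3)[nH]c2c1=O`, is the next step from compound 1: 4-bromo-3-fluorobenzyl in place of 3-bromophenyl on an amine nitrogen in a ring. Of the measured steps, an at least 1.0-fold lower number from compound 1 to compound 3 (0.03 log units; that floor lies within the scatter) bears on it most directly, since compound 3 also carries a benzyl group on that nitrogen and differs from compound 4 only in the substitution on the benzyl ring; compound 2 adds nothing beyond its own limit. The expectation in this assay is thus a value near that of compound 3, with a real chance of a limit again. Compound 4 is expected at 900 nM, within 400 nM to 2000 nM. This estimate for compound 4 means an expected step of an at least 1.1-fold lower number from compound 1 to compound 4 (0.04 log units; that floor lies within the scatter), a downward move that may not clear the scatter.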

Compound 4, inhibition constant: 326 nM
Beside the measured number, compound 4's estimate is 2.8-fold (0.44 log units) above it; measured number below the stated range.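

In this assay, substitution on the benzyl ring now gives a step beyond the scatter: a 2.8-fold lower number from compound 3 to compound 4 (0.45 log units; beyond the scatter), with 4-bromo-3-fluorophenyl in place of 3-bromophenyl on a saturated chain carbon bound to an amine nitrogen in a ring. Within the data shown here, the steps of an at least 3.0-fold lower number from compound 1 to compound 4 (0.48 log units; beyond the scatter) and an at least 3.0-fold lower number from compound 2 to compound 4 (0.48 log units; beyond the scatter) are the first from the phenyl compounds to clear the scatter, though both are floors because their starting values are limits: the limit of > 1000 nM in this assay, at which 2 of the 4 values shown sit. The group on this ring nitrogen can therefore move the number by more than the scatter, which the earlier floors, all within the scatter, could not show.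

The two changes on the benzyl ring stay unseparated, as the 4-bromo-3-fluorobenzyl group differs from 3-bromobenzyl in both the bromine's place and the added fluorine, so a plain 4-bromobenzyl or 3-fluorobenzyl group would be needed to assign the step. Also open, going by these compounds, is how a longer chain between the ring nitrogen and the aromatic ring, or an amine or carboxylic acid on that ring, would read here.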